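The source may hold more compounds than are shown below. What is called first, only, known or untested is meant among the compounds shown, and "the series" means these compounds.

Notes on the series.

Compound 1 `CN(C)/C=N/c1c(C=O)c(-c2ccc(Cl)cc2)nn1-c1cccc(Cl)c1` and compound 2 `CN(C)/C=N/c1c(C=O)c(-c2ccc(Cl)cc2)nn1-c1ccc(Br)cc1` share one core; compound 3 `Cc1ccc(-c2nn(-c3cccc(Cl)c3)c(N)c2C=O)cc1` and compound 4 `Cc1ccc(-c2nn(-c3ccc(Br)cc3)c(N)c2C=O)cc1` share another. The difference between the two cores is not broken down here. In a functional assay on Jurkat cells (Homo sapiens) for inhibition, read by MTT assay, with a stated time of 72 h (a lower number here means a stronger inhibitor of growth, a higher number a weaker inhibitor of growth), compound 1 gives 7700 nM. In this assay compound 2 gives 38900 nM. The change 4-bromophenyl in place of 3-chlorophenyl on an aromatic nitrogen made a 5.1-fold higher number from compound 1 to compound 2 (0.70 log units; beyond the scatter). In this assay compound 3 gives 86300 nM, the highest number of the three measured; compound 2 stands nearest to it and compound 1 furthest, both gaps beyond the scatter.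

Compound 4 carries the same kind of change on the core of compound 3: 4-bromophenyl in place of 3-chlorophenyl on an aromatic nitrogen. The surroundings are not word for word the same: in compound 3 the aromatic nitrogen is next to the ring atom that bears an amino group and two ring bonds from the ring atom that bears a 4-methylphenyl group, whereas in compound 1 it is next to the ring atom that bears a group of 5 heavy atoms and two ring bonds from the ring atom that bears a 4-chlorophenyl group. Within the data shown here, only one measured instance of the change exists, so its transfer to the second core rests on a single step.

The expectation for compound 4 in this assay is a step of a 4.1-fold higher number from compound 3 to compound 4 (0.61 log units; beyond the scatter), estimated to be of roughly the size seen in a 5.1-fold higher number from compound 1 to compound 2 (0.70 log units; beyond the scatter). Compound 4 is therefore expected at about 350000 nM, estimated to lie between 120000 nM and 1000000 nM. Since compound 3 already gives the highest number of the three measured, a number this high for compound 4 may fall outside the range the assay reports.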

Compound 4, concentration for 50% growth inhibition: 34400 nM
For compound 4 the middle estimate is 10-fold (1.01 log units) above the measured one; the whole stated range lies above it.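

In this assay, 4-bromophenyl in place of 3-chlorophenyl on the aromatic nitrogen gives a 2.5-fold lower number from compound 3 to compound 4 (0.40 log units; beyond the scatter), and set beside the earlier step the change does not keep its direction from one core to the other: the same change on two cores in this assay, a 5.1-fold higher number (0.70 log units; beyond the scatter) from compound 1 to compound 2 and a 2.5-fold lower number (0.40 log units; beyond the scatter) from compound 3 to compound 4, 13-fold (1.10 log units) apart, beyond the scatter of two such steps

For these two cores, then, the step read on one core does not predict the step on the other, neither in size nor in sign, so this change cannot be treated as a transferable increment in this series. Among these compounds, what this does not show is which difference between the cores goes with the reversal, the amino group and 4-methylphenyl group of compound 3 or the corresponding groups of compound 1, and each core contributes only a single step, so nothing can be said of how the change behaves on any further core.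

The compounds shown leave open whether the halogen or its place on the phenyl ring governs each step, which a 3-bromophenyl or a 4-chlorophenyl group on the aromatic nitrogen would separate. Also open, on these data alone, is how an unsubstituted phenyl group there, or a nitrile or a carboxylic acid in place of the formyl group, would read on either core.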